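Replacing the chloro of compound 1 with a piperazinyl group

A few compounds are considered here, and "the series" means these few. Any claim that something is new, unique, unknown or untested is made for them only; others in the source may bear on it.

Compound 1 `Cn1c(-c2ccc(NC(=O)CCl)cc2)nc(-c2ccccc2)c1-c1ccccc1` is the starting point of this step. Going by the values given here, in a functional assay on HT-29 cells (Homo sapiens) for cytotoxicity, read by MTT assay, with a stated time of 24 h, tested at 0.64 ug/mL (a higher number here means a stronger effect of the compound at the concentration tested, a lower number a weaker effect), compound 1 gives 7.2%, the lowest of the three numbers measured so far, although the other two lie within the scatter of it. Compound 2 `Cc1ccc2oc(SCC(=O)Nc3ccc(-c4nc(-c5ccccc5)c(-c5ccccc5)n4C)cc3)nc2c1` gives 11% and compound 3 `Cn1ccnc1SCC(=O)Nc1ccc(-c2nc(-c3ccccc3)c(-c3ccccc3)n2C)cc1` gives 13.6%. The steps of a number 3.8 percentage points higher from compound 1 to compound 2 (within the scatter) and a number 6.4 percentage points higher from compound 1 to compound 3 (within the scatter) both stay within the scatter, as does the step of a number 2.6 percentage points higher from compound 2 to compound 3 (within the scatter) between the two replacements.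

Compound 4 `CN(C)/C=C/N1CCN(CC(=O)Nc2ccc(-c3nc(-c4ccccc4)c(-c4ccccc4)n3C)cc2)CC1` differs from compound 1 in one place: 4-(2-(dimethylamino)ethenyl)piperazin-1-yl in place of chloro on a saturated chain carbon bound to a carbonyl carbon. The two measured steps from compound 1 bear on this change, since each of them also replaces the chloro on the same saturated chain carbon bound to the carbonyl carbon, and each stayed within the scatter. No step beyond the scatter is therefore expected here either, and the estimated step is a number 2.8 percentage points higher from compound 1 to compound 4 (within the scatter). Compound 4 is expected to give about 10%, with a range from 2% to 20%.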

Compound 4, a percentage reported as activity, at one concentration (the size of the read-out at that concentration, not a potency): 3.1%
The estimate for compound 4 lay 6.9 percentage points above the measured number; the range from low to high includes it.
By their numbers in this assay, from the lowest: compounds 4, 1, 2 and 3 (each within the scatter of the next, the first and the last beyond it).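

In this assay, the change on the saturated chain carbon bound to a carbonyl carbon now yields a step beyond the scatter, a number 10.5 percentage points lower from compound 3 to compound 4 (beyond the scatter), while the other two steps, a number 4.1 percentage points lower from compound 1 to compound 4 (within the scatter) and a number 7.9 percentage points lower from compound 2 to compound 4 (within the scatter), remain as printed. Exchanging the single chlorine for 4-(2-(dimethylamino)ethenyl)piperazin-1-yl, with its 11 heavy atoms, therefore does not move the number beyond the scatter, and only the comparison with the (1-methyl-1H-imidazol-2-yl)sulfanyl group separates the compounds at this position. Nothing measured here bears on why this step arises.

The compounds shown leave open whether the piperazine ring or the 2-(dimethylamino)ethenyl group on it accounts for the gap. A plain piperazin-1-yl or a morpholin-4-yl group at this position would help separate the two.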